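This account rests on a few compounds, and the source may have more. Where it says the series, first, only, none or still open, it means among the compounds named here.

Working notes on the thromboxane synthase series.

Compound 1 `O=C(O)CCC/C=C(/c1ccccc1)c1cccnc1` is the reference point. Going by the values given here, in an assay (Equus caballus) for inhibition of Thromboxane-A synthase (Homo sapiens), using microsomes (a higher number here means a weaker inhibitor, a lower number a stronger inhibitor), compound 1 gives 280 nM, the highest of the three numbers measured so far. Compound 2 `O=C(O)CCCC/C=C(\c1cccnc1)c1cccc(Br)c1` gives 180 nM, which lies within the scatter of compound 1. Compound 3 `O=C(O)CCCC/C=C(/c1ccc(F)cc1)c1cccnc1` gives 83 nM, a lower number than compound 1 and beyond the scatter. Among the compounds with values here, the only single-point step among the measured compounds is a 2.2-fold lower number from compound 2 to compound 3 (0.34 log units; beyond the scatter), and it concerns the aryl group on the double-bonded chain carbon, not the acid-bearing chain.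

Compound 4 `CC(C)(CCCC/C=C(/c1ccccc1)c1cccnc1)C(=O)O` is the next compound to be measured. Relative to compound 1 the change is 2-carboxy-2-methylpropyl in place of carboxy on a saturated chain carbon, three bonds along the chain from a double-bonded chain carbon. Within the data shown here, no measured step touches this part of the structure, so there is nothing among the measured pairs that bears directly on it; the acid-bearing chain is the same length in compound 2 and compound 3, and those two differ from compound 1 elsewhere as well. The expectation for this assay is therefore a step of modest size at most, a 1.4-fold lower number from compound 1 to compound 4 (0.15 log units; within the scatter), with wide uncertainty in either direction. Compound 4 is estimated at 200 nM, with a range from 50 nM to 800 nM.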

Compound 4, half-maximal inhibitory concentration: 38 nM
Compound 4: the middle estimate sits 5.3-fold (0.72 log units) above what was measured; measured number below the stated range.
By their numbers in this assay, from the lowest: compound 4; then compound 3; then compounds 2 and 1 (each within the scatter of the next).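

Going by these compounds alone, the acid-bearing chain of compound 1 is therefore not a silent part of the structure in this assay: on the saturated chain carbon, three bonds along the chain from a double-bonded chain carbon, the change gives a 7.4-fold lower number from compound 1 to compound 4 (0.87 log units; beyond the scatter), and this is the first measured step at this position. The terminal carboxy is not lost in this change, as 2-carboxy-2-methylpropyl still carries 1 hydrogen-bond donor, 1 hydrogen-bond acceptor and no net charge, while the group grows from 3 to 7 heavy atoms and still contains no ring. No measurement to hand explains the gain at this position.

Within the data shown here, the single step leaves unresolved how much of the gain belongs to the added chain length and how much to the methyl branching, and an unbranched 2-carboxyethyl group in the same place on the core of compound 1 would separate the two. Going by these compounds, it also remains open whether the gain carries over to a core bearing 4-fluorophenyl or 3-bromophenyl, and whether a tetrazole could stand in for the carboxylic acid at the end of this chain.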